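Aryl thiourea ethers: cytotoxicity notes toward compound 4

A few compounds are considered here, and "the series" means these few. Any claim that something is new, unique, unknown or untested is made for them only; others in the source may bear on it.

Measured compounds:
compound 1 `NC(=S)Nc1cccc(OCCCCc2ccccc2)c1`; in an ADME assay on Ava5 cells (Homo sapiens) for cytotoxicity (on this read-out higher numbers stand for lower toxicity in this test and lower numbers for higher toxicity in this test), compound 1 gives > 50000 nM, which is a limit of the assay and not a number.
compound 2 `NC(=S)Nc1cccc(OCCCCCCCc2ccccc2)c1`; in this assay compound 2 gives 23000 nM.
compound 3 `NC(=S)Nc1cccc(OCCCCCOc2cccc3ccccc23)c1`; in this assay compound 3 gives 14000 nM.

Of the two numerical values, compound 2 holds the higher one, but its gap to compound 3 lies within the usual scatter, so no order between the two is read into it. The value of compound 1 is the limit of > 50000 nM in this assay, at which 1 of the 3 values shown sits. Within the data shown here, no step between measured compounds that differ in a single place is available. Compound 4 `NC(=S)Nc1cccc(OCCCCCOc2cccnc2)c1` has not yet been measured in this assay. It differs from compound 2 in one place: (pyridin-3-yl)oxy in place of phenethyl on a saturated chain carbon, five bonds along the chain from an oxygen on an aromatic ring. Among the measured compounds shown here, with no comparable measured step in hand, the expectation rests on the spread of the three values, two close numbers and one limit. The step that the estimate means, a 1.3-fold higher number from compound 2 to compound 4 (0.12 log units; within the scatter), is expected to stay within the usual scatter, if anything toward a higher number. Compound 4 is estimated at 30000 nM, within a range from 12000 nM to 70000 nM.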

Compound 4, half-maximal cytotoxic concentration: > 50000 nM
Compound 4 ended at the assay's limit; the forecaster's own chance of this, stated with the estimate: 30%; at least 1.6-fold (0.22 log units) between middle value and limit.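

In this assay, among these compounds, (pyridin-3-yl)oxy in place of phenethyl on a saturated chain carbon, five bonds along the chain from an oxygen on an aromatic ring, gives the first readable single-place step: an at least 2.1-fold higher number from compound 2 to compound 4 (0.33 log units; beyond the scatter). This shows that the read-out at this position responds to the change, which brings in a ring with a hetero atom and hydrogen-bond acceptors that phenethyl lacks. Compound 4 gives > 50000 nM, which is a limit of the assay and not a number, so the step has a floor but no measured size, and the series now gathers at that limit: the limit of > 50000 nM in this assay, at which 2 of the 4 values shown sit.

Whether the ring nitrogen or the oxygen of the entering group accounts for the step stays open, as compound 4 differs from compound 2 in both at once. From the compounds shown here alone, how a phenoxy group or an amine would read at this place also remains open.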